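Aminophenyl in place of fluorophenyl: the next step

The source may report more compounds than this note shows. Statements on the series, on what has been measured and on what is new or still open speak of the compounds shown alone.

Two compounds carry numbers in a functional assay on BMDM cells (Mus musculus, strain C57BL/6) for inhibition, with a stated time of 2 days; on this read-out lower numbers stand for stronger inhibition and higher numbers for weaker inhibition. Compound 1 `CCOC(=O)c1sc(NC(=O)Cn2cc(-c3cccs3)nn2)nc1C` gives 20 nM in this assay. Compound 2 `O=C(Cn1cc(-c2ccc(F)cc2)nn1)Nc1nccs1` gives 190 nM in this assay, the higher of the two numbers, and the gap to compound 1 is beyond the usual scatter. For the measured compounds named here, the two compounds differ in more than one place, so no single step between them is given; their two values show only that compound 2 sits well above compound 1.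

Compound 3 `Nc1cccc(-c2cn(CC(=O)Nc3nccs3)nn2)c1` is the next compound, not yet measured in this assay. It differs from compound 2 in one place: 3-aminophenyl in place of 4-fluorophenyl on an aromatic carbon. Going by the values given here, nothing among the measured compounds bears on this particular change, and no other compound with 3-aminophenyl has a number here. The expected step is therefore a 1.1-fold higher number from compound 2 to compound 3 (0.02 log units; within the scatter), with no direction claimed beyond the scatter. Compound 3 is estimated at 200 nM, with a range from 60 nM to 650 nM.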

Compound 3, half-maximal inhibitory concentration: 1270 nM
Estimate against measurement, compound 3: 6.4-fold (0.80 log units) below, and the stated range ends below it.
By their numbers in this assay, from the lowest: compound 1; then compound 2; then compound 3.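

The step of a 6.7-fold higher number from compound 2 to compound 3 (0.83 log units; beyond the scatter) in this assay shows that this aromatic carbon of the five-membered ring is sensitive to the group it carries, which compound 1 and compound 2 could not show because they differ in more than one place. The change replaces fluorine with nitrogen and adds 1 hydrogen-bond donor and 1 hydrogen-bond acceptor, but it also changes the substituent's ring position, from 4-fluorophenyl to 3-aminophenyl, so this one step cannot separate the identity of the group from its placement. Nothing on hand accounts for the size or direction of the step.

Open, going by these compounds, is whether 4-aminophenyl or 3-fluorophenyl would stay closer to compound 2 or to compound 3. Also open, on these data alone, is whether an acetamide or a carboxylic acid on the phenyl ring would be tolerated here.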